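The source may report more compounds than this note shows. Statements on the series, on what has been measured and on what is new or still open speak of the compounds shown alone.

Measured so far:
- Compound 1 `CC(=O)Oc1ccc(C(=O)Nc2cc3ccc(OC4CCN(C)CC4)c(C)c3oc2=O)cc1`: 1620 nM
- Compound 2 `C=CCc1cc(C(=O)Nc2cc3ccc(OC4CCN(C)CC4)c(C)c3oc2=O)ccc1O`: 2170 nM

In a functional assay on MCF7 cells (Homo sapiens) for antiproliferative activity (on this read-out higher numbers stand for weaker inhibition and lower numbers for stronger inhibition), compound 2 gives 2170 nM. Among the measured compounds shown here, only one other number is available, and the two cannot be told apart: a 1.3-fold higher number from compound 1 to compound 2 (0.13 log units; within the scatter).

Compound 3 `Cc1c(OC2CCN(C)CC2)ccc2cc(NC(=O)c3ccc(O)cc3)c(=O)oc12` is compound 2 with hydrogen in place of allyl on an aromatic carbon, ortho to a hydroxy group: hydrogen in place of allyl on an aromatic carbon.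

For the measured compounds named here, only one measured step bears on this change. Compound 2 carries the allyl group and compound 1 does not, yet a 1.3-fold higher number from compound 1 to compound 2 (0.13 log units; within the scatter). Going by the values given here, that step also swaps acetoxy for hydroxy, so it is only indirect evidence, and no measured pair isolates the allyl group. Nothing therefore points to a clear shift in either direction. The expected change is a 1.1-fold lower number from compound 2 to compound 3 (0.04 log units; within the scatter), so no step beyond the scatter is expected. For compound 3 the estimated value is 2000 nM, with an expected range of 800 nM to 5500 nM.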

Compound 3, half-maximal inhibitory concentration: 1430 nM
Beside the measured number, compound 3's estimate is 1.4-fold (0.15 log units) above it; the measured number falls inside the stated range.
By their numbers in this assay, from the lowest: compounds 3, 1 and 2 (each within the scatter of the next).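

Among the compounds shown here, compound 3 gives the first direct look at this position, ortho to a hydroxy group. Allyl is the only group that differs from compound 2. In this assay, the comparison gives a 1.5-fold lower number from compound 2 to compound 3 (0.18 log units; within the scatter), so the two compounds cannot be told apart, and the allyl group leaves no readable mark on the number. The same holds for hydrogen in place of acetyl on the oxygen, which gives a 1.1-fold lower number from compound 1 to compound 3 (0.05 log units; within the scatter), and this time the comparison isolates that one difference, which the step between the first two compounds could not do. No supporting measurement bears on these results.

From the compounds shown here alone, whether a longer chain or a carboxylic acid at the allyl position would move the number beyond the scatter stays open. So does the effect of a methyl group on that oxygen.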